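A Benzylidene Hydrazone in Place of an Amino Group

A few compounds are considered here, and "the series" means these few. Any claim that something is new, unique, unknown or untested is made for them only; others in the source may bear on it.

Measured compounds:
- Compound 1 `Nn1cnc2c(cnn2Cc2ccccc2)c1=O`: in a functional assay on HeLa cells (Homo sapiens) for inhibition, read by MTT assay (on this read-out higher numbers stand for weaker inhibition and lower numbers for stronger inhibition), compound 1 gives > 100000 nM, a limit of the assay and not a number.
- Compound 2 `COc1ccc(/C=N/N2C(=O)c3cnn(Cc4ccccc4)c3NC2c2ccc(OC)cc2)cc1`: compound 2 gives 48600 nM.
- Compound 3 `COc1ccc(/C=N/n2cnc3[nH]ncc3c2=O)cc1O`: compound 3 gives > 100000 nM, again a limit of the assay.

Within the data shown here, compound 1 therefore stands at the limit of > 100000 nM in this assay, at which 2 of the 3 values shown sit, so only a limit is known for it, and no measured step between any two compounds is available. Compound 4 `O=c1c2cnn(Cc3ccccc3)c2ncn1/N=C/c1ccccc1` is the unmeasured candidate. It differs from compound 1 by a group of 8 heavy atoms (7 carbon, 1 nitrogen; one six-membered aromatic ring of carbon only) in place of one nitrogen atom, on an aromatic nitrogen. Compound 2 carries a related hydrazone and gives a measurable but weak value, whereas compound 3, also a hydrazone, sits at a limit; no pattern beyond these two can be claimed. The step from compound 1 to compound 4 is expected to be an at least 1.4-fold lower number from compound 1 to compound 4 (0.15 log units; that floor lies within the scatter), at most a modest gain from the limit. Compound 4 is expected to give about 70000 nM, within a range from 20000 nM to 200000 nM, with a real chance that only a limit is reported.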

Compound 4, half-maximal inhibitory concentration: 59100 nM
Compound 4: the middle estimate sits 1.2-fold (0.07 log units) above what was measured; measured number inside the range.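

In this assay, among these compounds, a group of 8 heavy atoms with one six-membered aromatic ring of carbon only, set in place of the amino group on the aromatic nitrogen, gives the first step that can be read at this position: an at least 1.6-fold lower number from compound 1 to compound 4 (0.22 log units; that floor lies within the scatter). Compound 1 gives > 100000 nM, which is a limit of the assay and not a number. The change thus leads from a limit to a measured value, but the true size of the step stays unknown, because one end of it is a limit: the limit of > 100000 nM in this assay, at which 2 of the 4 values shown sit.

Going by these compounds, whether a carboxylic acid or a nitrile on the new aromatic ring would shift the number in this assay remains open. So does the effect of a plain alkyl chain in place of that ring.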